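This account rests on a few compounds, and the source may have more. Where it says the series, first, only, none or still open, it means among the compounds named here.

Measured so far:
- compound 1, `Nc1nn(C(=O)Nc2ccc(Cc3ccccc3)cc2)c2ccccc12`: 13900 nM
- compound 2, `COc1ccccc1NC(=O)n1nc(N)c2ccccc21`: 98700 nM

In a functional assay on U-251 cells (Homo sapiens) for inhibition, read by sulforhodamine B assay, with a stated time of 48 h (a lower number here means a stronger inhibitor of growth, a higher number a weaker inhibitor of growth), compound 1 gives 13900 nM and holds the lowest number of the two; compound 2 gives 98700 nM, a gap that lies beyond the scatter. The two differ in more than one place, so no single-step reading between them is available.

Compound 3, `CCCCOc1ccc(NC(=O)n2nc(N)c3ccccc32)cc1`, is not yet measured. It differs from compound 1 in one place: butoxy in place of benzyl on an aromatic carbon. Going by the values given here, only one value with a six-membered aromatic ring in that position exists, that of compound 1, and no pair isolates this exchange, so the expected size of the step rests on compound 1 alone.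

Compound 3 is expected to land near compound 1, with a modest rise in the number considered more likely than a fall, giving an estimated 25000 nM with a range from 8000 nM to 80000 nM; this corresponds to an expected step of a 1.8-fold higher number from compound 1 to compound 3 (0.25 log units; within the scatter).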

Compound 3, concentration for 50% growth inhibition: 30500 nM
Compound 3: the middle estimate sits 1.2-fold (0.09 log units) below what was measured; the range from low to high includes it.
By their numbers in this assay, from the lowest: compound 1; then compound 3; then compound 2.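

In this assay, the aromatic carbon para to a large group gives the series its first single-place reading: butoxy in place of benzyl produces a 2.2-fold higher number from compound 1 to compound 3 (0.34 log units; beyond the scatter). The step is modest, so this position accepts a chain with no ring and still gives a measurable value, with compound 3 at 30500 nM, while benzyl gives the lower number of the two. No measurement shown here accounts for the step.

This exchange removes the aromatic ring, adds an oxygen and changes the group's size all at once, so the contribution of each remains unresolved. Phenoxy would keep the ring alongside the oxygen and pentyl would give a chain without the oxygen, while a carboxylic acid or an amine at this position would test a quite different kind of group.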